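Swapping the sulfur-bound side chain on a shared core

The source may hold more compounds than are shown below. What is called first, only, known or untested is meant among the compounds shown, and "the series" means these compounds.

Compound 2 `Cc1cc(Nc2cc(-c3ccccc3)[nH]n2)n2nc(SCC(=O)c3ccccc3)nc2n1` and compound 1 `Cc1cc(Nc2ccn(Cc3cccc4ccccc34)n2)n2nc(SCc3ccc(Br)cc3)nc2n1` share a core and were tested in a functional assay on MCF7 cells (Homo sapiens) for inhibition, read by MTT assay, with a stated time of 72 h; on this read-out higher numbers stand for weaker inhibition and lower numbers for stronger inhibition. Compound 1 gives 4310 nM. Compound 2 gives 5240 nM, a number that lies within the scatter of compound 1, so the two cannot be told apart.

Compound 3 `COc1ccc(CSc2nc3nc(C)cc(Nc4cc(-c5ccccc5)[nH]n4)n3n2)cc1` has not been measured. It differs from compound 2 in one place: 4-methoxyphenyl in place of benzoyl on a saturated chain carbon bound to a sulfur. Among the measured compounds shown here, with no measured step of this kind at hand, the change is expected to stay within the scatter, as a 1.2-fold lower number from compound 2 to compound 3 (0.07 log units; within the scatter). Compound 3 is therefore estimated at 4500 nM, with a range from 1800 nM to 11000 nM.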

Compound 3, half-maximal inhibitory concentration: 4020 nM
For compound 3 the middle estimate is 1.1-fold (0.05 log units) above the measured one; the measured number falls inside the stated range.
By their numbers in this assay, from the lowest: compounds 3, 1 and 2 (each within the scatter of the next).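

Among the compounds shown here, this is the first measured step at this position: in this assay 4-methoxyphenyl in place of benzoyl on a saturated chain carbon bound to a sulfur gives a 1.3-fold lower number from compound 2 to compound 3 (0.12 log units; within the scatter) and so leaves the two compounds indistinguishable. Within this pair, the benzoyl carbonyl is not needed to keep the number within the scatter. No measurement shown offers an explanation for this result. Still open, as far as these compounds go, is whether an amine, a carboxylic acid or a longer chain at this place would also stay within the scatter.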